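This account rests on a few compounds, and the source may have more. Where it says the series, first, only, none or still open, it means among the compounds named here.

Working notes on a small set run in a functional assay on Jurkat cells (Homo sapiens) for inhibition; a lower number here means a stronger inhibitor, a higher number a weaker inhibitor. Compound 1 `CCOC(=O)c1cnc(NN2C(=O)C=C(c3ccccc3)C2=O)nc1C(F)(F)F` gives 3700 nM, compound 2 `CCOC(=O)c1cnc(N(C(=O)c2ccccc2)N2C(=O)C=C(C)C2=O)nc1C(F)(F)F` gives 830 nM, and compound 3 `CCOC(=O)c1cnc(NN2C(=O)C=C(C)C2=O)nc1` gives 13000 nM, the highest of the three numbers. Compound 1 and compound 2 each differ from compound 3 in more than one place, so the gaps to them are recorded only as gaps, both beyond the scatter. Compound 4 `CCOC(=O)c1cnc(NN2C(=O)C=C(C)C2=O)nc1-c1nccs1` is not yet measured. It differs from compound 3 in one place: 1,3-thiazol-2-yl in place of hydrogen on an aromatic carbon. For the measured compounds named here, no single-change pair has been measured that would size such a step. Compound 1 at 3700 nM and compound 2 at 830 nM both sit lower than compound 3. On that basis a modest move toward a lower number is expected for a 2.6-fold lower number from compound 3 to compound 4 (0.41 log units; beyond the scatter), possibly not beyond the scatter. Compound 4 is estimated near 5000 nM, within 1500 nM to 15000 nM.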

Compound 4, half-maximal inhibitory concentration: 2200 nM
For compound 4 the middle estimate is 2.3-fold (0.36 log units) above the measured one; the range from low to high includes it.
By their numbers in this assay, from the lowest: compound 2; then compounds 4 and 1 (each within the scatter of the next); then compound 3.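

In this assay the change of hydrogen to 1,3-thiazol-2-yl gives a 5.9-fold lower number from compound 3 to compound 4 (0.77 log units; beyond the scatter) on the aromatic carbon next to the ring nitrogen and ortho to the ethoxycarbonyl group. This is the series' first single-change step, and it shows that this position accepts a five-membered aromatic ring with a gain in inhibition. Nothing at hand explains the size of the step. Still open, on these data alone, is how a phenyl ring, an amine or a carboxylic acid on this carbon would compare with 1,3-thiazol-2-yl.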